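Tetrazole substituent swap: ester in place of sulfonamide phenyl

The compounds below may be only part of what the source reports. "The series", "measured", "known", "first", "only" and "open" are said of these compounds alone.

Compound 3 `CCCCCCCCc1ccc(OCC(=O)Cn2nnc(-c3cccc(S(=O)(=O)N(C)C)c3)n2)cc1` gives 420 nM in an assay on microsomes from brain for inhibition of Fatty-acid amide hydrolase 1 (Rattus norvegicus), read by fluorescence and HPLC, with a stated time of 60 min (a lower number here means a stronger inhibitor, a higher number a weaker inhibitor), the highest number among the three measured. Compound 1 `CCCCCCCCc1ccc(OCC(=O)Cn2nnc(C)n2)cc1` gives 27 nM and compound 2 `CCCCCCCCc1ccc(OCC(=O)Cn2nnc(-c3ccccc3)n2)cc1` gives 24 nM in this assay . Compound 4 `CCCCCCCCc1ccc(OCC(=O)Cn2nnc(C(=O)OC)n2)cc1` differs from compound 3 in one place: methoxycarbonyl in place of 3-(dimethylsulfamoyl)phenyl on an aromatic carbon. Among the measured compounds shown here, the steps that bear on this change are a 16-fold higher number from compound 1 to compound 3 (1.19 log units; beyond the scatter) and an 18-fold higher number from compound 2 to compound 3 (1.24 log units; beyond the scatter), both large, whereas a 1.1-fold lower number from compound 1 to compound 2 (0.05 log units; within the scatter) stayed within the scatter. Compound 4 carries a group of far fewer heavy atoms, like the methyl of compound 1 at 27 nM, so a large step back toward lower numbers is expected. For compound 4 the estimate is 40 nM, with a range of 12 nM to 150 nM, which corresponds to an expected step of an 11-fold lower number from compound 3 to compound 4 (1.02 log units; beyond the scatter).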

Compound 4, half-maximal inhibitory concentration: 88 nM
The estimate for compound 4 lay 2.2-fold (0.34 log units) below the measured number; the measured number falls inside the stated range.
By their numbers in this assay, from the lowest: compounds 2 and 1 (each within the scatter of the next); then compound 4; then compound 3.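

In this assay, methoxycarbonyl recovers part of the loss seen with 3-(dimethylsulfamoyl)phenyl, with a 4.8-fold lower number from compound 3 to compound 4 (0.68 log units; beyond the scatter), but does not match methyl or phenyl, with a 3.3-fold higher number from compound 1 to compound 4 (0.51 log units; beyond the scatter) and a 3.7-fold higher number from compound 2 to compound 4 (0.56 log units; beyond the scatter). Heavy-atom count alone therefore does not order these numbers: compound 4 carries fewer heavy atoms than compound 2 yet gives the higher number. Nothing available explains why methoxycarbonyl differs from methyl or phenyl. Still open, from the compounds shown here alone, is how a carboxylic acid or a primary amide at this place would compare with methoxycarbonyl.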